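Benzylsulfanyl in place of 4,4-dimethylpiperidin-1-yl on the core

The compounds below may be only part of what the source reports. "The series", "measured", "known", "first", "only" and "open" are said of these compounds alone.

Compound 1 `CC(C(=O)NCc1ccc(C(F)(F)F)cc1N1CCC(C)(C)CC1)c1ccc(NS(C)(=O)=O)c(F)c1` gives the lowest number of the two measured in an assay on CHO cells for antagonist activity at transient receptor potential cation channel subfamily V member 1 (Homo sapiens), read by FLIPR (on this read-out higher numbers stand for weaker inhibition and lower numbers for stronger inhibition), namely 1.3 nM. Compound 2 `C[C@@H](C(=O)NCc1ccc(C(F)(F)F)cc1SC1CCCCC1)c1ccc(NS(C)(=O)=O)c(F)c1` gives 13.9 nM in this assay, a higher number that lies beyond the scatter. Compound 3 `CC(C(=O)NCc1ccc(C(F)(F)F)cc1SCc1ccccc1)c1ccc(NS(C)(=O)=O)c(F)c1` differs from compound 1 by benzylsulfanyl in place of 4,4-dimethylpiperidin-1-yl on an aromatic carbon. Going by the values given here, no measured pair covers exactly this change. A weakening of moderate size is expected for the step of a 7.7-fold higher number from compound 1 to compound 3 (0.89 log units; beyond the scatter), because compound 2 in this assay gives 13.9 nM. Compound 3 is therefore estimated at 10 nM in this assay, within a range from 3 nM to 40 nM.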

Compound 3, inhibition constant: 0.5 nM
Estimate against measurement, compound 3: 20-fold (1.30 log units) above; measured number below the stated range.
By their numbers in this assay, from the lowest: compound 3; then compound 1; then compound 2.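

At the aromatic carbon meta to a trifluoromethyl group, benzylsulfanyl in place of 4,4-dimethylpiperidin-1-yl gives a 2.6-fold lower number from compound 1 to compound 3 (0.41 log units; beyond the scatter) in this assay and so loses no inhibition. This position therefore accepts a sulfur-attached group carrying an aromatic ring as well as the non-aromatic nitrogen ring, at the same count of heavy atoms. Nothing measured here accounts for the step.

Going by these compounds alone, the single change swaps the attached atom and the ring together, so their separate contributions remain open. A benzyloxy or benzylamino group at this position would separate them.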